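The source may hold more compounds than are shown below. What is called first, only, known or untested is meant among the compounds shown, and "the series" means these compounds.

Measured compounds:
compound 1, `Oc1cccc(-c2cc(-c3ccsc3)cc(-c3cccc(O)c3)n2)c1`, gives 4.5% in an assay on isolated protein for inhibition of DNA topoisomerase 1 (Homo sapiens), with a stated time of 30 min, tested at 20 uM; a higher number here means a stronger effect of the compound at the concentration tested, a lower number a weaker effect;
compound 2, `Oc1cccc(-c2cc(-c3cccnc3)cc(-c3ccccc3O)n2)c1`, gives 0% in this assay.

Among the measured compounds shown here, compound 2 holds the lowest of the two numbers so far, and its nearest neighbour is compound 1, whose number lies higher by an amount within the scatter of the assay, so the two cannot be ranked against each other. For the measured compounds named here, no step between two measured compounds that differ in a single place is available.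

Compound 3, `Oc1cccc(-c2cc(-c3cccnc3)cc(-c3cccc(O)c3)n2)c1`, differs from compound 2 in one place: 3-hydroxyphenyl in place of 2-hydroxyphenyl on an aromatic carbon. The only sign of what such a change might do is that compound 1, which also carries two 3-hydroxyphenyl groups, gave 4.5% in this assay, a number near the bottom of the scale. A step of a number 3 percentage points higher from compound 2 to compound 3 (within the scatter) is therefore expected, which is no change beyond the scatter. Compound 3 is estimated to give 3%, with a range from 0% to 12%.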

Compound 3, a percentage reported as inhibition, at one concentration (the size of the read-out at that concentration, not a potency): 1.9%
Beside the measured number, compound 3's estimate is 1.1 percentage points above it; measured number inside the range.
By their numbers in this assay, from the lowest: compounds 2, 3 and 1 (each within the scatter of the next).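

In this assay, 3-hydroxyphenyl in place of 2-hydroxyphenyl on the aromatic carbon next to the ring nitrogen gives a number 1.9 percentage points higher from compound 2 to compound 3 (within the scatter) and so does not separate the two groups at this position. A second place can now be read too: pyridin-3-yl in place of thiophen-3-yl gives a number 2.6 percentage points lower from compound 1 to compound 3 (within the scatter) and leaves these two groups equally unseparated. No measurement is at hand that would account for either step.

Since all three compounds lie within the scatter of one another, the compounds shown do not reveal any group that alters the read-out. Going by these compounds, it stays open whether an amine or a carboxylic acid in place of the hydroxyl group, on either hydroxyphenyl ring, would give a number clearly apart from these.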